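A few compounds are considered here, and "the series" means these few. Any claim that something is new, unique, unknown or untested is made for them only; others in the source may bear on it.

Compound 1 `COc1cccc(N2C(=O)COc3ccc(-c4cnc(Cl)c(NS(=O)(=O)c5ccc(F)cc5)c4)cc32)c1`: > 40000 nM (a limit, not a number)
Compound 2 `COc1ccc(N2C(=O)COc3ccc(-c4cnc(Cl)c(NS(=O)(=O)c5ccc(F)cc5)c4)cc32)cc1`: 8320 nM
Compound 3 `COc1cccc(N2C(=O)COc3ccc(-c4ccc(O)cc4)cc32)c1`: > 40000 nM (a limit, not a number)

For the measured compounds named here, in a functional assay on HeLa cells (Homo sapiens) for antiproliferative activity, read by MTT assay, with a stated time of 72 h (a higher number here means a weaker inhibitor, a lower number a stronger inhibitor), compound 2 stands at 8320 nM, the only true number among the three. The other two compounds rest at the limit of > 40000 nM in this assay, at which 2 of the 3 values shown sit. Compound 2 is therefore the sole measured reference point for what follows.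

Compound 4 `Cc1ccc(N2C(=O)COc3ccc(-c4cnc(Cl)c(NS(=O)(=O)c5ccc(F)cc5)c4)cc32)cc1` keeps the rest of compound 2 and alters one group: methyl in place of methoxy on an aromatic carbon. In words, this is methyl in place of methoxy on an aromatic carbon, para to a large group, turning 4-methoxyphenyl into 4-methylphenyl.

Going by the values given here, one measured step bears on this phenyl group: an at least 4.8-fold lower number from compound 1 to compound 2 (0.68 log units; beyond the scatter). That step shows that a change on this group can register in this assay. However, it moves the methoxy rather than replacing it, so it does not indicate a direction for the swap to methyl. Among the compounds with values here, no measured compound carries methyl here. With so little to go on, no step beyond the usual scatter is expected, in either direction, though the uncertainty is wide. The expected change is a 1.1-fold higher number from compound 2 to compound 4 (0.03 log units; within the scatter). For compound 4 the estimated value is 9000 nM, expected to fall between 3500 nM and 25000 nM.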

Compound 4, half-maximal inhibitory concentration: 32300 nM
For compound 4 the middle estimate is 3.6-fold (0.55 log units) below the measured one; the whole stated range lies below it.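

Methyl in place of methoxy on this phenyl group is not a neutral swap: in this assay, the change gives a 3.9-fold higher number from compound 2 to compound 4 (0.59 log units; beyond the scatter), so the identity of the group at this place counts, and not only whether it sits in the 4-methoxyphenyl or 3-methoxyphenyl arrangement. Replacing 3-methoxyphenyl with 4-methylphenyl gives an at least 1.2-fold lower number from compound 1 to compound 4 (0.09 log units; that floor lies within the scatter), and as that floor lies within the scatter, this step cannot show that the two compounds truly differ. Compound 1 carries a limit of the assay, not a number, and the same is true of compound 3: the limit of > 40000 nM in this assay, at which 2 of the 4 values shown sit.

Among the groups shown at this place, methoxy in the 4-methoxyphenyl arrangement gives the only step clearly beyond the scatter in both comparisons, but the compounds shown leave open whether an ethoxy, a hydroxyl or an amine at the same carbon would match it or go beyond it. They also give no explanation for the loss on moving to methyl, and they leave open whether the same swap would have a similar effect on a different core.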